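This account rests on a few compounds, and the source may have more. Where it says the series, first, only, none or still open, it means among the compounds named here.

Measured so far:
compound 1, `O=C(/C=C\Nc1ccc(F)cc1)c1cn(-c2ccccc2)nc1-c1ccccc1`, 10200 nM;
compound 2, `O=C(/C=C\Nc1ccc(Cl)cc1)c1cn(-c2ccccc2)nc1-c1ccccc1`, 11400 nM;
compound 3, `COc1ccc(-c2nn(-c3ccccc3)cc2C(=O)/C=C\Nc2ccc(F)cc2)cc1`, 8910 nM.

In a functional assay on U-87MG ATCC cells (Homo sapiens) for antiproliferative activity, read by MTT assay, with a stated time of 48 h (a lower number here means a stronger inhibitor, a higher number a weaker inhibitor), these three compounds give numbers that all sit close together. Compound 2 differs from compound 1 by chloro in place of fluoro on an aromatic carbon, and this change gave a 1.1-fold higher number from compound 1 to compound 2 (0.05 log units; within the scatter). Compound 3 differs from compound 1 in the core, by methoxy in place of hydrogen on an aromatic carbon, and that change gave a 1.1-fold lower number from compound 1 to compound 3 (0.06 log units; within the scatter). Compound 4, `COc1ccc(-c2nn(-c3ccccc3)cc2C(=O)/C=C\Nc2ccc(Cl)cc2)cc1`, has not yet been measured in this assay. Among the measured compounds shown here, it differs from compound 3 by chloro in place of fluoro on an aromatic carbon, which is the same change as the one from compound 1 to compound 2, made on the core of compound 3 instead of the core of compound 1.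

The expected step is a 1.1-fold higher number from compound 3 to compound 4 (0.04 log units; within the scatter), because in this assay the same change gave a 1.1-fold higher number from compound 1 to compound 2 (0.05 log units; within the scatter), and compound 3 gave 8910 nM as the starting point. Compound 4 is therefore estimated to give 9800 nM in this assay, with a range expected from 5000 nM to 19000 nM.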

Compound 4, half-maximal inhibitory concentration: 8860 nM
Beside the measured number, compound 4's estimate is 1.1-fold (0.04 log units) above it; measured number inside the range.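

In this assay, chloro in place of fluoro on the core of compound 3 gave a 1.0-fold lower number from compound 3 to compound 4 (0.00 log units; within the scatter), and this agrees with the earlier step: the same change on two cores in this assay, a 1.1-fold higher number (0.05 log units; within the scatter) from compound 1 to compound 2 and a 1.0-fold lower number (0.00 log units; within the scatter) from compound 3 to compound 4, 1.1-fold (0.05 log units) apart, within the scatter of two such steps. Methoxy in place of hydrogen, now read on the chloro pair, gave a 1.3-fold lower number from compound 2 to compound 4 (0.11 log units; within the scatter), and this also agrees with its earlier step: the same change on two cores in this assay, a 1.1-fold lower number (0.06 log units; within the scatter) from compound 1 to compound 3 and a 1.3-fold lower number (0.11 log units; within the scatter) from compound 2 to compound 4, 1.1-fold (0.05 log units) apart, within the scatter of two such steps. Among the compounds shown here, all of these steps lie within the scatter, so the agreement shows only that neither change shifted the number measurably on these cores; it does not show that a change with a real effect would carry from one core to another in the same way.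

The four compounds carry only fluoro or chloro on the ring of the phenylamino group, and only hydrogen or methoxy on the other varied ring. As far as these compounds go, whether a carboxylic acid or a dimethylamino group in the place of the chloro, or a longer alkoxy chain in the place of the methoxy, would give a step beyond the scatter remains open.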